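Ester to acid step in the growth inhibition series

This account rests on a few compounds, and the source may have more. Where it says the series, first, only, none or still open, it means among the compounds named here.

Measured so far in a functional assay on A549 cells (Homo sapiens) for inhibition, read by sulforhodamine B assay, with a stated time of 72 h; on this read-out lower numbers stand for stronger inhibition of growth and higher numbers for weaker inhibition of growth:
- Compound 1 (`CCOC(=O)/C=C/c1ccncc1-c1ccc2[nH]ccc2c1`) gives 7440 nM
- Compound 2 (`CCOC(=O)/C=C/c1ccncc1-c1ccc2c(ccn2C)c1`) gives 1720 nM

Compound 2 holds the lowest of the two numbers. Compound 3 (`Cn1ccc2cc(-c3cnccc3/C=C/C(=O)O)ccc21`) differs from it by hydrogen in place of ethyl on an oxygen next to a carbonyl group. For the measured compounds named here, the only measured step, a 4.3-fold lower number from compound 1 to compound 2 (0.64 log units; beyond the scatter) (modest), is methyl in place of hydrogen on an aromatic nitrogen, so it offers a scale but no direction. Going by the values given here, no measured step touches the ester. In this assay a tentative step of similar order toward a higher number is expected, estimated as a 4.7-fold higher number from compound 2 to compound 3 (0.67 log units; beyond the scatter) (direction uncertain). The estimate for compound 3 is 8000 nM with an expected range of 2000 nM to 30000 nM (not yet measured).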

Compound 3, concentration for 50% growth inhibition: > 10000 nM
Compound 3: a limit, no number; the forecaster's own chance of this, stated with the estimate: 15%; middle value at least 1.2-fold (0.09 log units) from the limit.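

In this assay compound 3 gives > 10000 nM, which is a limit and not a number: the limit of > 10000 nM in this assay, at which 1 of the 3 values shown sits. The change from ethoxycarbonyl to carboxy gives an at least 5.8-fold higher number from compound 2 to compound 3 (0.76 log units; beyond the scatter), so the ester position now has a measured direction, toward weaker inhibition of growth, though the size of the step has only a floor. The earlier step at the aromatic nitrogen gave no reading at this place.

Going by these compounds, the full size of the step remains open. Also open, on these data alone, is how a methyl ester, a primary amide or a longer chain on that oxygen would compare with compound 2.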